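Working notes: methyl in place of methoxy, compound 4

The source may report more compounds than this note shows. Statements on the series, on what has been measured and on what is new or still open speak of the compounds shown alone.

Compound 1 `COc1ccc(OC(=O)Nc2ccc([Se]C#N)cc2)cc1` is measured in a functional assay on HT-29 cells (Homo sapiens) for cytotoxicity, read by MTT assay, with a stated time of 72 h (on this read-out higher numbers stand for weaker inhibition of growth and lower numbers for stronger inhibition of growth), at 41500 nM. Compound 2 `CCCCOC(=O)Nc1ccc([Se]C#N)cc1` gives 31300 nM in this assay, and compound 3 `CC(C)COC(=O)Nc1ccc([Se]C#N)cc1` gives 31300 nM. Compound 1 holds the highest of the three numbers, but its gap to compound 2 and its gap to compound 3 both fall within the scatter, so the three compounds are not separable on these figures. Within the data shown here, the single step between measured compounds, no change at the digits printed from compound 2 to compound 3 (within the scatter), concerns the saturated chain on the oxygen of the carbamate and leaves the aromatic ring untouched.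

Compound 4 `Cc1ccc(OC(=O)Nc2ccc([Se]C#N)cc2)cc1` differs from compound 1 by methyl in place of methoxy on an aromatic carbon. Among the measured compounds shown here, no measured step bears directly on this change; the one step available lies elsewhere in the molecule and showed nothing beyond the scatter, and the whole measured set sits within a narrow band. The step from compound 1 to compound 4 in this assay is therefore expected to stay within the scatter, a 1.0-fold lower number from compound 1 to compound 4 (0.02 log units; within the scatter). Compound 4 is estimated at 40000 nM, with a range from 20000 nM to 80000 nM.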

Compound 4, concentration for total growth inhibition: 38800 nM
Estimate against measurement, compound 4: 1.0-fold (0.01 log units) above; the measured number falls inside the stated range.
By their numbers in this assay, from the lowest: compounds 2, 3, 4 and 1 (each within the scatter of the next).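

Methyl in place of methoxy on an aromatic carbon, para to a large group, gives a 1.1-fold lower number from compound 1 to compound 4 (0.03 log units; within the scatter) in this assay. Among these compounds, this is the first step made on an aromatic ring rather than on a saturated chain, and it shows that the two compounds cannot be separated on this read-out even though methoxy, with its oxygen and its counted hydrogen-bond acceptor, is gone. No independent data bear on this result, so what lies behind it remains unknown.

The compounds shown leave open whether any group at this position can move the number beyond the scatter, for instance an amine, a carboxylic acid or a chlorine atom. They also leave open whether a longer chain in place of methyl would separate from compound 4.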